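The compounds below may be only part of what the source reports. "The series", "measured", "known", "first", "only" and "open" are said of these compounds alone.

Compound 3 `O=C1NC(=O)c2c1c1c3ccccc3ccc1c1c2c2ccccc2n1[C@@H]1O[C@H](CO)[C@@H](O)[C@H]1O` stands at the low end of three numbers that all lie within the scatter of one another: in a functional assay on MDA-MB-435 cells (Homo sapiens) for cytotoxicity (a lower number here means a stronger inhibitor, a higher number a weaker inhibitor), compound 3 gives 3200 nM, compound 2 `O=C1NC(=O)c2c1c1c3ccccc3ccc1c1c2c2ccccc2n1[C@H]1OC[C@@H](O)[C@@H](O)[C@H]1O` gives 3300 nM and compound 1 `C[C@@H]1O[C@@H](n2c3ccccc3c3c4c(c5c6ccccc6ccc5c32)C(=O)NC4=O)[C@H](O)[C@H](O)[C@H]1O` gives 3600 nM. Compound 4 `O=C1NC(=O)c2c1c1c3ccccc3ccc1c1c2c2ccccc2n1[C@H]1C[C@H](O)[C@@H](CO)O1` differs from compound 3 by hydrogen in place of hydroxy on a saturated ring carbon. Among the compounds with values here, no measured step removes a single hydroxy; each exchanges the whole group on the aromatic nitrogen, and each stayed within the scatter: a 1.1-fold lower number from compound 1 to compound 2 (0.04 log units; within the scatter), a 1.1-fold lower number from compound 1 to compound 3 (0.05 log units; within the scatter) and a 1.0-fold lower number from compound 2 to compound 3 (0.01 log units; within the scatter). Because those changes to the same part of the molecule gave a 1.1-fold lower number from compound 1 to compound 3 (0.05 log units; within the scatter), the step of no change at the digits printed from compound 3 to compound 4 (within the scatter) is expected to be small, with no direction beyond the scatter. Compound 4 is therefore estimated at 3200 nM, within a range from 1500 nM to 7000 nM.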

Compound 4, half-maximal inhibitory concentration: 4100 nM
The estimate for compound 4 lay 1.3-fold (0.11 log units) below the measured number, and the stated range covers the measured number.
By their numbers in this assay, from the lowest: compounds 3, 2, 1 and 4 (each within the scatter of the next).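

In this assay, hydrogen in place of hydroxy on this saturated ring carbon gives the first single-hydroxy step, a 1.3-fold higher number from compound 3 to compound 4 (0.11 log units; within the scatter), so this one hydroxy carries no readable weight here. The larger exchanges of the whole group on the aromatic nitrogen also stay within the scatter: a 1.2-fold higher number from compound 2 to compound 4 (0.09 log units; within the scatter) and a 1.1-fold higher number from compound 1 to compound 4 (0.06 log units; within the scatter). No supporting measurement offers an explanation for this flat result.

As far as these compounds go, whether an amine, a methoxy group or fluorine on this same ring carbon would move the number beyond the scatter remains open. So does whether the neighbouring hydroxy or the hydroxymethyl group can be exchanged as freely.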